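The source may report more compounds than this note shows. Statements on the series, on what has been measured and on what is new or still open speak of the compounds shown alone.

In a functional assay on HCT-116 cells (Homo sapiens) for antiproliferative activity, read by sulforhodamine B assay, with a stated time of 72 h (on this read-out higher numbers stand for weaker inhibition and lower numbers for stronger inhibition), three compounds have been measured:

compound 1, `CC(=O)NCC[C@@H]1C[C@@H](c2ccc(F)c(F)c2)[C@H](NC(=O)c2cc(-c3c(Cl)cnn3C)c(Cl)o2)CN1`, 920 nM;
compound 2, `Cn1ncc(Cl)c1-c1cc(C(=O)N[C@@H]2CN[C@H](CCN3CCCCC3)C[C@H]2c2ccc(Cl)c(Cl)c2)oc1Cl`, 1020 nM;
compound 3, `Cn1ncc(Cl)c1-c1cc(C(=O)N[C@H]2CNCC[C@@H]2c2ccc(C(F)(F)F)cc2)oc1Cl`, 1050 nM.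

Compound 2 stands second highest of these three numbers. Its nearest neighbour is compound 3 and its furthest is compound 1, and both gaps lie within the scatter, so the three compounds are not told apart on this assay.

Compound 4 `Cn1ncc(Cl)c1-c1cc(C(=O)N[C@@H]2CN[C@H](CC(=O)NCCO)C[C@H]2c2ccc(Cl)c(Cl)c2)oc1Cl` has not yet been measured. It differs from compound 2 in one place:

(2-hydroxyethyl)carbamoyl in place of (piperidin-1-yl)methyl on a saturated chain carbon bound to a saturated ring carbon

Going by the values given here, no pair of measured compounds differs in one place, so there is no measured step to set beside this change, and the expectation rests on the three close numbers alone. On this assay the step is expected to be small, more likely toward weaker inhibition than toward stronger, and it may well stay within the scatter: a 1.8-fold higher number from compound 2 to compound 4 (0.25 log units; within the scatter). Compound 4 is therefore estimated at 1800 nM, within a range from 600 nM to 6000 nM.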

Compound 4, half-maximal inhibitory concentration: 670 nM
For compound 4 the middle estimate is 2.7-fold (0.43 log units) above the measured one; the range from low to high includes it.
By their numbers in this assay, from the lowest: compounds 4, 1, 2 and 3 (each within the scatter of the next).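

In this assay, the place on a saturated chain carbon bound to a saturated ring carbon accepts (2-hydroxyethyl)carbamoyl in place of (piperidin-1-yl)methyl with a 1.5-fold lower number from compound 2 to compound 4 (0.18 log units; within the scatter) and no more than that. Going by these compounds alone, the six-membered non-aromatic ring of the leaving group can therefore be replaced by an open chain carrying a carbonyl and a hydroxyl without a change that stands out from the scatter, which the earlier compounds, none of them one change apart, could not show. Nothing measured here accounts for this result.

As far as these compounds go, whether a carboxylic acid, a primary amine or a longer chain at this place would give a step beyond the scatter stays open. So does the part played by the terminal hydroxyl, which a plain methylcarbamoyl would test.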